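Swapping a Propyl for Cyclopropyl on the Amine Nitrogen

A few compounds are considered here, and "the series" means these few. Any claim that something is new, unique, unknown or untested is made for them only; others in the source may bear on it.

Three compounds share one core and differ only in the group on the nitrogen bound to it. Compound 1 `CCCN(C)c1nc(C)nc2c(-c3c(C)cc(OC)cc3OC)c(C)nn12` gives 6.48 nM in an assay on cell membranes for displacement of a labelled ligand from corticotropin-releasing factor receptor 1 (Rattus norvegicus); on this read-out higher numbers stand for weaker inhibition and lower numbers for stronger inhibition. Compound 2 `CCC1CCCCN1c1nc(C)nc2c(-c3c(C)cc(OC)cc3OC)c(C)nn12` gives 3.26 nM in this assay, and compound 3 `CCCN(CCC)c1nc(C)nc2c(-c3c(C)cc(OC)cc3OC)c(C)nn12` gives 3.72 nM. Compound 3 thus sits second highest of the three numbers, and the steps of a 1.1-fold higher number from compound 2 to compound 3 (0.06 log units; within the scatter) and a 1.7-fold lower number from compound 1 to compound 3 (0.24 log units; within the scatter) both fall inside the scatter. Compound 4 `CCCN(c1nc(C)nc2c(-c3c(C)cc(OC)cc3OC)c(C)nn12)C1CC1` carries cyclopropyl in place of propyl on a nitrogen on an aromatic ring, so dipropylamino becomes cyclopropyl(propyl)amino. The two steps that bear on this, a 1.7-fold lower number from compound 1 to compound 3 (0.24 log units; within the scatter) and a 1.1-fold higher number from compound 2 to compound 3 (0.06 log units; within the scatter), each reshaped the groups on this same nitrogen without moving the number beyond the scatter, so no step beyond the scatter is expected here either. Compound 4 is therefore estimated at 4 nM, within 1.5 nM to 11 nM, an expected step of a 1.1-fold higher number from compound 3 to compound 4 (0.03 log units; within the scatter).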

Compound 4, half-maximal inhibitory concentration: 1.48 nM
The estimate for compound 4 lay 2.7-fold (0.43 log units) above the measured number, outside the stated range (below it).
By their numbers in this assay, from the lowest: compound 4; then compounds 2, 3 and 1 (each within the scatter of the next).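

In this assay the swap of propyl for cyclopropyl on this nitrogen gives a 2.5-fold lower number from compound 3 to compound 4 (0.40 log units; beyond the scatter) and so moves the number beyond the scatter, which neither earlier change of the groups here did. Compound 4 also separates from the other two compounds, with a 2.2-fold lower number from compound 2 to compound 4 (0.34 log units; beyond the scatter) and a 4.4-fold lower number from compound 1 to compound 4 (0.64 log units; beyond the scatter) as further steps beyond the scatter. Nothing shown here explains this difference. Still open, as far as these compounds go, is whether a cyclobutyl or an isopropyl group on this nitrogen would behave like cyclopropyl, and whether a second cyclopropyl in place of the remaining propyl would extend the step.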